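A few compounds are considered here, and "the series" means these few. Any claim that something is new, unique, unknown or untested is made for them only; others in the source may bear on it.

In an ADME assay on a cell-free system (plasma, Mus musculus) for metabolic stability, read by HPLC, with a stated time of 120 min, tested at 2 uM (on this read-out higher numbers stand for a longer-lived compound and lower numbers for a shorter-lived compound), compound 3 (`O=C(NCCCCc1ccccc1)n1cnc2ccccc21`) gives > 2 h, which is a limit and not a number. Compound 1 (`COc1nc2ccccc2n1C(=O)NCCCCc1ccccc1`) gives > 2 h, also a limit. Compound 3 thus stands at the limit of > 2 h in this assay, at which 2 of the 3 values shown sit. Compound 2 (`O=C(NCCCCc1ccccc1)N1C(=O)c2ccccc2C1=O`), by contrast, gives a true number of 0.383 h.

The next compound, compound 4 (`CCCCCCNC(=O)n1cnc2ccccc21`), differs from compound 3 as follows: ethyl in place of phenyl on a saturated chain carbon, four bonds along the chain from an amide-type nitrogen. In short, it carries ethyl in place of phenyl on a saturated chain carbon, four bonds along the chain from an amide-type nitrogen.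

Going by the values given here, only one measured step connects compounds that differ in one place, a step that the two limits leave unreadable from compound 1 to compound 3, and its size cannot be read. Among the compounds with values here, that step swaps hydrogen for methoxy on an aromatic carbon, and no measured compound shows what replacing phenyl with ethyl does. The expectation therefore rests on compound 3, whose reading of > 2 h is a limit. No step beyond the usual scatter is expected in this assay, and no direction can be favoured. The expected change is a step that the limit leaves unreadable from compound 3 to compound 4. For compound 4, the half-life is estimated at 3 h, with an expected range from 1.2 h to 8 h.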

Compound 4, half-life: > 2 h
Compound 4 gave a limit, no number; the forecaster's own chance of this, stated with the estimate: 65%; the middle value lies beyond the limit too.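

Going by these compounds alone, compound 3 and compound 4 both give only a limit in this assay, so no step between them can be read. The compounds shown leave open how long either compound actually lasts, and whether ethyl in place of phenyl on this saturated chain carbon alters the half-life at all.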